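A few compounds are considered here, and "the series" means these few. Any claim that something is new, unique, unknown or untested is made for them only; others in the source may bear on it.

The shared core runs through three measured compounds and one still to be measured. Compound 1 `COc1cc(-c2nnc(SCc3cccc(Br)c3)o2)ccc1O` gives 48100 nM in a functional assay on cells (T-cell, Mus musculus, strain BALB/c) for inhibition, read by MTT assay, with stated times of 24 h and 72 h; on this read-out higher numbers stand for weaker inhibition and lower numbers for stronger inhibition. Compound 2 `COc1cc(-c2nnc(SCc3ccc(C)cc3)o2)ccc1O` gives 6210 nM in this assay, and compound 3 `COc1cc(-c2nnc(SCc3ccc(F)cc3F)o2)ccc1O` gives 9690 nM in this assay. Compound 3 stands second highest of the three numbers: its nearest neighbour is compound 2, within the scatter, while compound 1 lies further off, as shown by a 5.0-fold lower number from compound 1 to compound 3 (0.70 log units; beyond the scatter). Compound 4 `COc1cc(-c2nnc(SCc3cccc(Cl)c3)o2)ccc1O` differs from compound 3 in one place: 3-chlorophenyl in place of 2,4-difluorophenyl on a saturated chain carbon bound to a sulfur. Because a 5.0-fold lower number from compound 1 to compound 3 (0.70 log units; beyond the scatter) covered the move from 3-bromophenyl to 2,4-difluorophenyl, and 3-chlorophenyl resembles 3-bromophenyl, that step bears most on the present change, and a 7.7-fold lower number from compound 1 to compound 2 (0.89 log units; beyond the scatter) points the same way. Partly undoing that step, a higher number is expected for compound 4, with an expected step of a 3.1-fold higher number from compound 3 to compound 4 (0.49 log units; beyond the scatter). Compound 4 is therefore estimated at 30000 nM, with a range from 8000 nM to 90000 nM.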

Compound 4, half-maximal inhibitory concentration: 8290 nM
Beside the measured number, compound 4's estimate is 3.6-fold (0.56 log units) above it, within the range that was stated.
By their numbers in this assay, from the lowest: compounds 2, 4 and 3 (each within the scatter of the next); then compound 1.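

In this assay, the change from 2,4-difluorophenyl to 3-chlorophenyl on a saturated chain carbon bound to a sulfur is a 1.2-fold lower number from compound 3 to compound 4 (0.07 log units; within the scatter), and the change from 4-methylphenyl to 3-chlorophenyl is a 1.3-fold higher number from compound 2 to compound 4 (0.13 log units; within the scatter), so these three groups cannot be told apart at this place. Chloro in place of bromo on an aromatic carbon, by contrast, gives a 5.8-fold lower number from compound 1 to compound 4 (0.76 log units; beyond the scatter), so 3-chlorophenyl groups with the other two and not with 3-bromophenyl, from which it differs only in that halogen. Nothing shown gives a reason for this difference.

On these data alone, it remains open whether 3-iodophenyl would group with 3-bromophenyl or with 3-chlorophenyl. Also open, as far as these compounds go, is how an unsubstituted phenyl, or a longer chain on the sulfur, would compare with these four compounds.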